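Methyl on the aryl ring: from compound 3 to compound 4

The compounds below may be only part of what the source reports. "The series", "measured", "known", "first", "only" and "open" are said of these compounds alone.

Measured in an assay on CHO cells for displacement of a labelled ligand from histamine receptor H3 (Macaca mulatta), read by scintillation counting, with a stated time of 1 h; a higher number here means a weaker inhibitor, a lower number a stronger inhibitor:
compound 1 `CC(=O)N(C)C1CCN(C(=O)Nc2ccc(N3CCC(N4CCCC4C)C3)cc2)C1` gives 35.5 nM
compound 2 `CC(=O)N(C)C1CCN(C(=O)Nc2ccc(N3CCC(N4CCCC4C)C3)c(C)c2)C1` gives 89.7 nM
compound 3 `CC1CCCN1C1CCN(c2ccc(NC(=O)Nc3ccc(Oc4ccccc4)cc3)cc2)C1` gives 46.8 nM

Compound 1 and compound 2 differ by one change, (methyl in place of hydrogen on an aromatic carbon), and in this assay this made a 2.5-fold higher number from compound 1 to compound 2 (0.40 log units; beyond the scatter). Compound 3 carries a different core; the difference between the two cores is not broken down here, and its value sits within the scatter of compound 1.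

Compound 4 `Cc1cc(NC(=O)Nc2ccc(Oc3ccccc3)cc2)ccc1N1CCC(N2CCCC2C)C1` has not yet been measured. It arises from compound 3 by the same kind of change, (methyl in place of hydrogen on an aromatic carbon), but here the methyl sits ortho to a 3-(2-methylpyrrolidin-1-yl)pyrrolidin-1-yl group and meta to a large group, whereas in compound 2 it sits ortho to a large group and meta to a large group.

For compound 4 a step of about the same size is expected, a 2.5-fold higher number from compound 3 to compound 4 (0.39 log units; beyond the scatter), because a 2.5-fold higher number from compound 1 to compound 2 (0.40 log units; beyond the scatter). Compound 4 is therefore estimated at 115 nM in this assay, with a likely range from 55 nM to 240 nM.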

Compound 4, inhibition constant: 115 nM
The estimate for compound 4 equals the measured number at the digits printed; measured number inside the range.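

In this assay, methyl in place of hydrogen on an aromatic carbon gave a 2.5-fold higher number from compound 3 to compound 4 (0.39 log units; beyond the scatter). The same replacement therefore carried over to a second core with its size kept: the same change on two cores in this assay, a 2.5-fold higher number (0.40 log units; beyond the scatter) from compound 1 to compound 2 and a 2.5-fold higher number (0.39 log units; beyond the scatter) from compound 3 to compound 4, 1.0-fold (0.01 log units) apart, within the scatter of two such steps. For the compounds shown here, this rests on only two pairs, however, and it shows neither that the step would hold on a further core nor why it has this size.

The compounds shown leave open whether an ethyl group or a fluorine atom on the same aromatic carbon would shift the number as methyl does. They also leave open what methyl would do on another carbon of that ring.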